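A few compounds are considered here, and "the series" means these few. Any claim that something is new, unique, unknown or untested is made for them only; others in the source may bear on it.

Three compounds share one core. Within the data shown here, in a functional assay on A549 cells (Homo sapiens) for inhibition, read by sulforhodamine B assay, with a stated time of 48 h, tested at 10 uM (on this read-out higher numbers stand for more inhibition at the one concentration tested (going by the name of the read-out) and lower numbers for less inhibition), compound 1 `c1cn2cc(-c3ccsc3)nc(-c3ccc4ncn(C5CCCCC5)c4c3)c2n1` gives 3.97%, and compound 2 `COc1ccccc1-c1cn2ccnc2c(-c2ccc3ncn(C4CCCCC4)c3c2)n1` gives 13.9%; the single one-place step seen so far is a number 9.9 percentage points higher from compound 1 to compound 2 (within the scatter). Compound 3 `CCc1ccc(-c2cn3ccnc3c(-c3ccc4ncn(Cc5ccccc5)c4c3)n2)cc1` gives 45.4% in this assay and stands highest of the three, beyond the scatter from both others. Compound 4 `Cc1cccc(-c2cn3ccnc3c(-c3ccc4ncn(Cc5ccccc5)c4c3)n2)c1` differs from compound 3 by 3-methylphenyl in place of 4-ethylphenyl on an aromatic carbon. Among the measured compounds shown here, no measured step swaps one substituted phenyl for another at the same point of the core; the only step known there concerns a different pair of groups and lay within the scatter. With nothing bearing directly on this change, the expected step is a number 9.4 percentage points lower from compound 3 to compound 4 (within the scatter), small enough that it may fall within the scatter. Compound 4 is estimated at 36%, between 15% and 57%.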

Compound 4, a percentage reported as inhibition, at one concentration (the size of the read-out at that concentration, not a potency): 14.9%
The estimate for compound 4 lay 21.1 percentage points above the measured number; measured number outside the range, below it.
By their numbers in this assay, from the lowest: compounds 1, 2 and 4 (each within the scatter of the next, the first and the last beyond it); then compound 3.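

Among these compounds, the change to 3-methylphenyl in place of 4-ethylphenyl, a number 30.5 percentage points lower from compound 3 to compound 4 (beyond the scatter), shows that this position responds strongly even to an exchange between two substituted phenyl groups, which the one earlier step there did not show. Neither group has any hydrogen-bond donors, hydrogen-bond acceptors or net charge, yet the step is large. Nothing available accounts for this step.

The compounds shown leave open whether the step goes with the methyl or the placement of the group, which 4-methylphenyl and 3-ethylphenyl would separate. They also leave open how an amine or a carboxylic acid on this phenyl ring would read.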